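The compounds below may be only part of what the source reports. "The series", "measured", "known", "first", "only" and "open" are said of these compounds alone.

Compound 1 `COc1ccc2nc(SCC(=O)N(Cc3ccc(OC)c(O)c3)c3cc(OC)c(OC)c(OC)c3)sc2c1`: 352 nM
Compound 2 `COc1ccc(CN(C(=O)CSc2nc3cc(Cl)ccc3s2)c2cc(OC)c(OC)c(OC)c2)cc1O`: 429 nM
Compound 3 `COc1ccc(CN(C(=O)CSc2nc3c(C)cccc3s2)c2cc(OC)c(OC)c(OC)c2)cc1O`: 852 nM

In a functional assay on HCT-116 cells (Homo sapiens) for antiproliferative activity, read by MTT assay, with a stated time of 48 h (on this read-out higher numbers stand for weaker inhibition and lower numbers for stronger inhibition), compound 3 gives 852 nM, which sets it apart only from compound 1: the two measured steps are a 2.4-fold higher number from compound 1 to compound 3 (0.38 log units; beyond the scatter) and a 2.0-fold higher number from compound 2 to compound 3 (0.30 log units; within the scatter). The unmeasured compound 4 `COc1ccc(CN(C(=O)CSc2nc3cc(Br)ccc3s2)c2cc(OC)c(OC)c(OC)c2)cc1O` differs from compound 3 by a group of 10 heavy atoms (7 carbon, 1 nitrogen, 1 sulfur, 1 bromine; one five-membered aromatic ring with 2 hetero atoms, one six-membered aromatic ring of carbon only) in place of a group of 10 heavy atoms (8 carbon, 1 nitrogen, 1 sulfur; one five-membered aromatic ring with 2 hetero atoms, one six-membered aromatic ring of carbon only), on a sulfur. For the measured compounds named here, no measured compound carries bromine, so this rests on the two steps above, which both introduced the 4-methyl-1,3-benzothiazol-2-yl group and both ran upward. Removing that group should therefore lower the number, by a step near the edge of the scatter. The expected change is a 2.0-fold lower number from compound 3 to compound 4 (0.31 log units; beyond the scatter). The estimate for compound 4 is 420 nM, with an expected range of 210 nM to 840 nM.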

Compound 4, half-maximal inhibitory concentration: 3380 nM
Beside the measured number, compound 4's estimate is 8.0-fold (0.91 log units) below it, outside the stated range (above it).
By their numbers in this assay, from the lowest: compounds 1, 2 and 3 (each within the scatter of the next, the first and the last beyond it); then compound 4.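

In this assay, for the compounds shown here, the group on the sulfur proves less tolerant than the earlier compounds suggested: bromo in place of chloro on an aromatic carbon gives a 7.9-fold higher number from compound 2 to compound 4 (0.90 log units; beyond the scatter) and so exceeds every earlier step. The other two comparisons agree, with a 4.0-fold higher number from compound 3 to compound 4 (0.60 log units; beyond the scatter) and a 9.6-fold higher number from compound 1 to compound 4 (0.98 log units; beyond the scatter), which makes compound 4 the weakest of the four. Nothing available accounts for the large difference between the chloro and bromo compounds. The compounds shown leave open whether this sharp rise is specific to bromo. A fluoro group or an amine in place of the bromo could test that.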